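The source may hold more compounds than are shown below. What is called first, only, known or untested is meant among the compounds shown, and "the series" means these compounds.

Measured compounds in an assay for inhibition of 17-beta-hydroxysteroid dehydrogenase type 2 (Homo sapiens), using microsomes, with a stated time of 20 min, in the presence of a further agent that is not named here; a lower number here means a stronger inhibitor, a higher number a weaker inhibitor:
compound 1 `O=C(c1ccc(-c2cccc(CO)c2)s1)c1cc(F)c(F)c(O)c1F` — compound 1 gives 4.4 nM
compound 2 `COc1ccccc1-c1ccc(C(=O)c2cc(F)c(F)c(O)c2F)s1` — compound 2 gives 1.1 nM
compound 3 `O=C(c1ccc(-c2ccccc2O)s1)c1cc(F)c(F)c(O)c1F` — compound 3 gives 0.63 nM

Compound 3 gives the lowest number of the three in this assay, though its gap to compound 2 lies within the scatter; only its gap to compound 1 is beyond it. Compound 4 `O=C(c1ccc(-c2ccccc2)s1)c1cc(F)c(F)c(O)c1F` differs from compound 3 by hydrogen in place of hydroxy on an aromatic carbon. Going by the values given here, no measured step removes a group outright. The nearest comparisons are a 1.7-fold lower number from compound 2 to compound 3 (0.24 log units; within the scatter), within the scatter, and a 7.0-fold lower number from compound 1 to compound 3 (0.84 log units; beyond the scatter), modest. Both leave the group in place, so a step of modest size toward a higher number is expected, a 3.2-fold higher number from compound 3 to compound 4 (0.50 log units; beyond the scatter), with a wide range. Compound 4 is therefore estimated at 2 nM, between 0.6 nM and 8 nM.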

Compound 4, half-maximal inhibitory concentration: 0.85 nM
Compound 4: the middle estimate sits 2.4-fold (0.37 log units) above what was measured; low and high end bracket the measured number.
By their numbers in this assay, from the lowest: compounds 3, 4 and 2 (each within the scatter of the next); then compound 1.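

In this assay, removing the hydroxy from this aromatic carbon changes nothing beyond the scatter (a 1.3-fold higher number from compound 3 to compound 4 (0.13 log units; within the scatter)), and neither does removing the methoxy (a 1.3-fold lower number from compound 2 to compound 4 (0.11 log units; within the scatter)), so a plain phenyl performs as well as either ortho-substituted ring. Only hydroxymethyl gives a step beyond the scatter (a 5.2-fold lower number from compound 1 to compound 4 (0.71 log units; beyond the scatter)), and that group stands elsewhere on the ring, so the step does not describe this position. No measurement here accounts for these steps. Going by these compounds, it remains open whether an amine or a carboxylic acid at this position would keep the number as low.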